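A few compounds are considered here, and "the series" means these few. Any claim that something is new, unique, unknown or untested is made for them only; others in the source may bear on it.

Compound 1 `Nc1ccccc1NC(=O)c1ccc(CSC(=S)N2CCN(c3ccc(Cl)cc3)CC2)cc1`: in a functional assay on A-375 cells (Homo sapiens) for antiproliferative activity, read by CCK-8 assay, with a stated time of 72 h, tested at 8 uM (a higher number here means a stronger effect of the compound at the concentration tested, a lower number a weaker effect), compound 1 gives 29%.
Compound 2 `Nc1ccccc1NC(=O)c1ccc(CSC(=S)N2CCN(c3ccccc3)CC2)cc1`: in this assay compound 2 gives 88.6%.

Compound 2 stands highest of the two numbers in this assay. Within the data shown here, the only step between measured compounds, a number 59.6 percentage points higher from compound 1 to compound 2 (beyond the scatter), is large. Compound 3 `Nc1ccccc1NC(=O)c1ccc(CSC(=S)N2CCN(c3ccc(F)cc3)CC2)cc1` differs from compound 2 by fluoro in place of hydrogen on an aromatic carbon. A halogen enters at the place where the chloro of compound 1 sat, so a fall in this assay is expected, though with one step only its size is uncertain. Compound 3 is estimated at 55%, range 22% to 88%, an expected step of a number 33.6 percentage points lower from compound 2 to compound 3 (beyond the scatter).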

Compound 3, a percentage reported as inhibition, at one concentration (the size of the read-out at that concentration, not a potency): 76.3%
For compound 3 the middle estimate is 21.3 percentage points below the measured one, within the range that was stated.
By their numbers in this assay, from the lowest: compound 1; then compound 3; then compound 2.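

In this assay, a halogen on the phenyl ring, para to a large group, does not by itself remove most of the effect: fluoro in place of hydrogen gives a number 12.3 percentage points lower from compound 2 to compound 3 (beyond the scatter), a modest step. The identity of the halogen matters far more in this small set, with fluoro in place of chloro giving a number 47.3 percentage points higher from compound 1 to compound 3 (beyond the scatter), a large step. Nothing available explains this difference between the halogens.

On these data alone, whether bromo, methoxy or an amine at this place would follow fluoro or chloro remains open. Single-concentration read-outs also leave the potencies of these compounds open.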